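The source may hold more compounds than are shown below. What is called first, only, known or untested is meant among the compounds shown, and "the series" means these compounds.

Measured compounds:
- compound 1, `COc1ccc(-c2cc(=O)c3c(OC)cc(OC)cc3n2C)cc1` — 28000 nM
- compound 2, `COc1ccc(-c2c(I)c(=O)c3c(OC)cc(OC)cc3n2S(=O)(=O)c2ccc(OC)cc2)cc1` — 12300 nM
- compound 3, `COC(=O)c1cc(=O)c2c(OC)cc(OC)cc2n1C` — a limit, > 37900 nM

In a functional assay on SUP-B15 cells (Homo sapiens) for antiproliferative activity, with a stated time of 72 h (a higher number here means that more compound is needed for the effect, a lower number that less compound is needed), compound 1 gives 28000 nM. Of the two plain numbers measured, compound 1 has the higher one; compound 2 sits lower, and that gap lies beyond the scatter. For compound 3 the assay reports only a limit, > 37900 nM, not a number.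

One measured step starts from compound 1. It is an at least 1.3-fold higher number from compound 1 to compound 3 (0.13 log units; that floor lies within the scatter), so the change at that carbon did not bring the number down. The new compound 4, `COc1ccc(-c2cc(=O)c3c(OC)cc(OC)cc3n2S(=O)(=O)c2ccc(F)cc2)cc1`, changes a different position: (4-fluorophenyl)sulfonyl in place of methyl on an aromatic nitrogen. Among the measured compounds shown here, no measured pair isolates exactly this change. Compound 2 does carry a related arylsulfonyl group on the same nitrogen, but it also carries iodine, so its two values with compound 1 can only be read side by side: compound 2 shows the lower number.

On that basis a modest move downward is expected, of a size not far beyond the scatter. Compound 4 is estimated at 15000 nM, with a range from 5000 nM to 40000 nM. This expectation corresponds to a 1.9-fold lower number from compound 1 to compound 4 (0.27 log units; within the scatter).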

Compound 4, half-maximal effective concentration: > 65500 nM
Compound 4: a limit, no number (the forecaster's own chance of this, stated with the estimate: 15%); at least 4.3-fold (0.64 log units) between middle value and limit.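

On the aromatic nitrogen of the shared core, (4-fluorophenyl)sulfonyl in place of methyl can now be read as a single change, and it gives an at least 2.3-fold higher number from compound 1 to compound 4 (0.36 log units; beyond the scatter). In this assay compound 4 is reported only as a limit and not as a number: the limit of > 65500 nM in this assay, at which 1 of the 4 values shown sits. A large arylsulfonyl group on this nitrogen therefore does not bring the number down on its own here, and compound 2, at 12300 nM, cannot be used as a guide to this change, as it carries iodine as well as a different arylsulfonyl group.

The compounds shown leave open how much of the number of compound 2 belongs to the iodine and how much to the methoxy group on its arylsulfonyl ring, as no single-change pair separates these two features. They also leave open how the number would respond to other groups on this nitrogen in place of methyl, such as a longer chain like butyl or a chain ending in an amine.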